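Aminophenyl enone series: methoxy count and cytotoxicity

The compounds below may be only part of what the source reports. "The series", "measured", "known", "first", "only" and "open" are said of these compounds alone.

Compound 2 `COc1cc(-c2cc(/C=C/C(=O)c3ccc(N)cc3)[nH]n2)cc(OC)c1OC` gives -55% in a functional assay on SF-268 cells (Homo sapiens) for cytotoxicity, read by sulforhodamine B assay, with a stated time of 48 h, tested at 10 uM (on this read-out lower numbers stand for a stronger effect and higher numbers for a weaker effect at the one concentration tested), the lowest of the two numbers at hand. The nearest, compound 1 `COc1ccc(-c2cc(/C=C/C(=O)c3ccc(N)cc3)[nH]n2)cc1`, gives -29% in this assay, a gap beyond the usual scatter. Going by the values given here, no step between measured compounds that differ in a single place is available, so any trend can only be read from these two values. Compound 3 `COc1ccc(-c2cc(/C=C/C(=O)c3ccc(N)cc3)[nH]n2)cc1OC` is not yet measured. Relative to compound 2 it differs in one place: hydrogen in place of methoxy on an aromatic carbon. Since compound 2 gives -55% and compound 1 gives -29%, fewer methoxy groups on that ring go with a higher number, and compound 3 sits between the two in methoxy count. The step of a number 13 percentage points higher from compound 2 to compound 3 (beyond the scatter) is therefore expected to be upward and modest, around the size of the scatter or a little beyond it. Compound 3 is estimated at -42%, within -62% to -20%.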

Compound 3, a percentage reported as activity, at one concentration (the size of the read-out at that concentration, not a potency): -49%
Compound 3: the middle estimate sits 7 percentage points above what was measured; the range from low to high includes it.
By their numbers in this assay, from the lowest: compounds 2 and 3 (each within the scatter of the next); then compound 1.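

In this assay, the step of a number 6 percentage points higher from compound 2 to compound 3 (within the scatter) lies within the scatter, so hydrogen in place of methoxy gives no readable change at this place, ortho to a methoxy group and meta to a large group. The step of a number 20 percentage points lower from compound 1 to compound 3 (beyond the scatter) lies beyond the scatter, so methoxy in place of hydrogen does count when it is added to the ring of compound 1. Read together, these two steps show that a further methoxy on the ring of compound 3 brings no readable gain, and nothing at hand gives a reason for this difference.

On these data alone, whether a hydroxyl group, a chlorine atom or an ethoxy group would read like methoxy at this place remains open. Also open, as far as these compounds go, is how a ring carrying no methoxy group at all would read.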